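Amide nitrogen substituent swap in a weak antagonist series

The source may report more compounds than this note shows. Statements on the series, on what has been measured and on what is new or still open speak of the compounds shown alone.

Three compounds have been measured in an in vitro functional assay on HEK ts201 cells for antagonist activity at Neuronal acetylcholine receptor; alpha4/beta2 (Homo sapiens), read by fluorescence and calcium flux; a lower number here means a stronger inhibitor, a higher number a weaker inhibitor:

Compound 1, `O=C(NCc1ccccc1)c1ccccc1-c1ccccc1`, gives 7500 nM.
Compound 2, `CC1(C)CC(=O)N(c2ccccc2C(=O)OCC2CCCN(CCCc3ccccc3)C2)C1=O`, gives 4900 nM.
Compound 3, `COc1ccc(OCCCCCN2CCCC(COC(=O)c3coc4ccccc4c3=O)C2)cc1`, gives 10000 nM.

Compound 1 stands second highest of the three numbers. Its nearest neighbour is compound 3, whose value of 10000 nM lies within the usual scatter of the value of compound 1. The furthest is compound 2, whose 4900 nM also lies within the scatter. Among the measured compounds shown here, on these numbers no compound can be singled out as stronger or weaker than the others; all three sit in the same weak range of this assay.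

The next compound, compound 4, `O=C(Nc1ccccc1)c1ccccc1-c1ccccc1`, keeps the core of compound 1 and differs in one place: phenyl in place of benzyl on an amide-type nitrogen. For the measured compounds named here, no step between two measured compounds is available to set the size of such a change in this assay, and the three measured structures have little in common with one another apart from their weak values.

The step from compound 1 to compound 4 is therefore expected to be small, most likely none beyond the scatter, as a 1.1-fold higher number from compound 1 to compound 4 (0.03 log units; within the scatter). Compound 4 is estimated at 8000 nM in this assay, within a range from 3000 nM to 25000 nM.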

Compound 4, half-maximal inhibitory concentration: 6900 nM
The estimate for compound 4 lay 1.2-fold (0.06 log units) above the measured number; measured number inside the range.
By their numbers in this assay, from the lowest: compounds 2, 4, 1 and 3 (each within the scatter of the next, the first and the last beyond it).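

In this assay, the series now has its first step that differs in one place: a 1.1-fold lower number from compound 1 to compound 4 (0.04 log units; within the scatter), with phenyl in place of benzyl on an amide-type nitrogen whose other neighbour is the carbonyl carbon. Benzyl (7 heavy atoms) and phenyl (6 heavy atoms) each carry one six-membered aromatic ring of carbon only, and on this one pair the exchange stays within the scatter, so this place on the core of compound 1 shows no measurable response to that change. No supporting evidence is available that bears on this result, and the step stands as a bare observation.

Steps that would link compound 2 or compound 3 to this pair cannot be read, so whether the same flat response holds on any other core remains unknown. Also open, on these data alone, is how this nitrogen responds to a group of a different kind, such as a longer chain like phenethyl, or a chain ending in an amine or a carboxylic acid, since the two groups compared here both keep the same aromatic ring.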